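The source may report more compounds than this note shows. Statements on the series, on what has been measured and on what is new or still open speak of the compounds shown alone.

Measured so far:
compound 1 `Cc1cc2occ(-c3nc(-c4ccccc4)c(-c4ccccc4)n3-c3ccccc3Cl)c(=O)c2cc1Cl` — 6250 nM
compound 2 `Cc1cc2occ(-c3nc(-c4ccccc4)c(-c4ccccc4)n3-c3cccc(Cl)c3)c(=O)c2cc1Cl` — 25000 nM
compound 3 `Cc1ccc(-n2c(-c3coc4cc(C)c(Cl)cc4c3=O)nc(-c3ccccc3)c2-c2ccccc2)cc1` — 6250 nM

In a functional assay on HepG2 cells (Homo sapiens) for inhibition, read by MTT assay, with a stated time of 72 h (a higher number here means a weaker inhibitor, a lower number a stronger inhibitor), compound 2 has the highest number of the three, which makes it the weakest inhibitor shown. Against its two neighbours the steps read a 4.0-fold higher number from compound 1 to compound 2 (0.60 log units; beyond the scatter) and a 4.0-fold lower number from compound 2 to compound 3 (0.60 log units; beyond the scatter). Compound 1 and compound 3 sit together, since no change at the digits printed from compound 1 to compound 3 (within the scatter).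

Compound 4 `Cc1cccc(-n2c(-c3coc4cc(C)c(Cl)cc4c3=O)nc(-c3ccccc3)c2-c2ccccc2)c1` is not yet measured. It differs from compound 2 by methyl in place of chloro on an aromatic carbon. The ring that carries this group is the one attached to the aromatic nitrogen of the shared core, so that the whole ring reads as 3-methylphenyl in place of 3-chlorophenyl.

Among the compounds with values here, none of the measured steps swaps chloro for methyl at the same place. Compound 3 carries 4-methylphenyl and gives a lower number than compound 2, while compound 1 carries 2-chlorophenyl and is also lower. Both steps are modest and point the same way, so compound 4 is expected to come out with a lower number than compound 2, the expected step being a 2.1-fold lower number from compound 2 to compound 4 (0.32 log units; beyond the scatter). Compound 4 is therefore estimated at 12000 nM, within 4000 nM to 40000 nM.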

Compound 4, half-maximal inhibitory concentration: 6250 nM
The estimate for compound 4 lay 1.9-fold (0.28 log units) above the measured number; the measured number falls inside the stated range.
By their numbers in this assay, from the lowest: compounds 1, 3 and 4 (each within the scatter of the next); then compound 2.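

In this assay, within the data shown here, putting methyl where chloro stood on the same aromatic carbon gives a clear change (a 4.0-fold lower number from compound 2 to compound 4 (0.60 log units; beyond the scatter)), the first direct comparison of these two groups at this place. The 3-methylphenyl ring also reads the same as the 4-methylphenyl ring (no change at the digits printed from compound 3 to compound 4 (within the scatter)) and the 2-chlorophenyl ring (no change at the digits printed from compound 1 to compound 4 (within the scatter)), so among these four compounds 3-chlorophenyl alone stands apart, with the other three rings indistinguishable. No measurement offered here explains why this one ring differs.

Going by these compounds, it remains open whether 4-chlorophenyl or 2-methylphenyl would sit with compound 2 or with the other three compounds. On these data alone, how a methoxy group, an amine or a carboxylic acid at this place would compare with methyl and chloro also remains open.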